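Biaryl sulfonamides in the shared core: step to compound 4

A few compounds are considered here, and "the series" means these few. Any claim that something is new, unique, unknown or untested is made for them only; others in the source may bear on it.

Measured in a functional assay on DLD-1 cells (Homo sapiens) for antiproliferative activity, read by CellTiter-Glo, with a stated time of 72 h; a higher number here means a weaker inhibitor, a lower number a stronger inhibitor:
compound 1 `CC1CCN(C2CCN(S(=O)(=O)c3cccc(C(F)(F)F)c3)CC2)CC1` gives > 5000 nM; this value is a limit of the assay.
compound 2 `CC1CCN(C2CCN(S(=O)(=O)c3cccc(-c4ccccc4F)c3)CC2)CC1` gives 10 nM.
compound 3 `CC1CCN(C2CCN(S(=O)(=O)c3cccc(-c4ccc5ccccc5c4)c3)CC2)CC1` gives 2 nM.

Compound 3 holds the lowest number of the two measured values, with compound 2 nearest by a 5.0-fold lower number from compound 2 to compound 3 (0.70 log units; beyond the scatter). Compound 4 `CC1CCN(C2CCN(S(=O)(=O)c3cccc(-c4ccccc4C(F)(F)F)c3)CC2)CC1` differs from compound 3 in one place: 2-(trifluoromethyl)phenyl in place of naphthalen-2-yl on an aromatic carbon. Among the compounds with values here, the steps that bear on this are an at least 500-fold lower number from compound 1 to compound 2 (2.69 log units; beyond the scatter) and an at least 2500-fold lower number from compound 1 to compound 3 (3.39 log units; beyond the scatter), which show that either aryl group brings a large drop relative to the trifluoromethyl of compound 1, and a 5.0-fold lower number from compound 2 to compound 3 (0.70 log units; beyond the scatter), a modest gap between the two aryl groups. Compound 4 carries a single six-membered aromatic ring as compound 2 does, so a modest rise from compound 3 is expected, a 7.5-fold higher number from compound 3 to compound 4 (0.88 log units; beyond the scatter). Compound 4 is therefore estimated at 15 nM in this assay, within 4 nM to 60 nM.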

Compound 4, half-maximal inhibitory concentration: 10 nM
The estimate for compound 4 lay 1.5-fold (0.18 log units) above the measured number; the range from low to high includes it.
By their numbers in this assay, from the lowest: compound 3; then compounds 2 and 4 (each within the scatter of the next). At a limit, above all of these: compound 1.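

In this assay, swapping the fluoro of the aryl group for trifluoromethyl gives no change at the digits printed from compound 2 to compound 4 (within the scatter), so these two aryl groups cannot be told apart here. Naphthalen-2-yl stays apart from this aryl group, with a 5.0-fold higher number from compound 3 to compound 4 (0.70 log units; beyond the scatter). Trifluoromethyl carried on a phenyl group, rather than on the aromatic carbon itself, gives an at least 500-fold lower number from compound 1 to compound 4 (2.69 log units; beyond the scatter), a step that rests on a limit: the limit of > 5000 nM in this assay, at which 1 of the 4 values shown sits.

On these data alone, whether the gap to compound 3 follows the second aromatic ring stays open. So does how an amine or a carboxylic acid on the aryl group would read in this assay.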